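A few compounds are considered here, and "the series" means these few. Any claim that something is new, unique, unknown or untested is made for them only; others in the source may bear on it.

Measured compounds:
Compound 1 `CC1=C(C(=O)OC2CCCCC2)C(c2csc(-c3ccc(Cl)cc3)n2)C(C(=O)OC2CCCCC2)=C(C)N1` gives 11000 nM in an assay on isolated protein for antagonist activity at Voltage-dependent L-type calcium channel subunit alpha-1C (Cavia porcellus), with a stated time of 15 min; a lower number here means a stronger inhibitor, a higher number a weaker inhibitor.
Compound 2 `CC1=C(C(=O)OCCc2ccccc2)C(c2csc(-c3ccc(Cl)cc3)n2)C(C(=O)OCCc2ccccc2)=C(C)N1` gives 500000 nM in this assay.
Compound 3 `COC(=O)C1=C(C)NC(C)=C(C(=O)OC(C)(C)C)C1c1csc(-c2ccc(Cl)cc2)n1` gives 46000 nM in this assay.

Among these three, compound 1 has the lowest number in this assay. Its nearest neighbour is compound 3, whose number is higher by a margin beyond the usual scatter, and compound 2 stands far above both, also well beyond the scatter. Among the compounds with values here, no pair of these measured compounds differs in a single place, so no single step can be read from them; the values only show that both the two-phenethyl-ester pairing of compound 2 and the methyl with tert-butyl pairing of compound 3 fall short of the two-cyclohexyl-ester pairing of compound 1.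

Compound 4 `CCOC(=O)C1=C(C)NC(C)=C(C(=O)OC2CCCCC2)C1c1csc(-c2ccc(Cl)cc2)n1` has not yet been measured. It differs from compound 1 by ethyl in place of cyclohexyl on an oxygen next to a carbonyl group, so that one ester is kept while the other is shortened to a two-carbon chain. Without a measured step of this kind, the expectation rests on compound 1 alone, whose 11000 nM sets the anchor. The change is modest in size, and the step from compound 1 to compound 4 is expected to be small, a 1.4-fold lower number from compound 1 to compound 4 (0.14 log units; within the scatter), most likely within the scatter or a slight move to a lower number. Compound 4 is therefore estimated at 8000 nM, with a plausible range from 2500 nM to 30000 nM.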

Compound 4, half-maximal inhibitory concentration: 100000 nM
Compound 4: the middle estimate sits 13-fold (1.10 log units) below what was measured; the whole stated range lies below it.
By their numbers in this assay, from the lowest: compound 1; then compound 3; then compound 4; then compound 2.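

In this assay, within the data shown here, the exchange of one cyclohexyl for ethyl on an oxygen next to a carbonyl group gives a 9.1-fold higher number from compound 1 to compound 4 (0.96 log units; beyond the scatter) and is the first change in this set that can be read on its own. Among these compounds, it shows that this position is not indifferent to the group it carries, which the earlier compounds could not show, as they differ from one another in more than one place. The second cyclohexyl ester stays in place in compound 4, so that one group alone does not preserve the number seen with compound 1, and no measurement shown here explains the step.

The compounds shown leave open whether the ring itself or simply the count of carbons on this oxygen accounts for the step, a question that an open hexyl chain with the same six carbons, or a smaller cyclopentyl ring, would help to separate. They also leave open how the same exchange would read on the other ester of compound 1, or whether a terminal amine on the ethyl chain would shift the number in either direction.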